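Replacing the Phenyl of Compound 3 with a Hydroxybutyl Chain

The source may report more compounds than this note shows. Statements on the series, on what has been measured and on what is new or still open speak of the compounds shown alone.

Three measured compounds share one core and differ only in the chain carried by the ring nitrogen. Compound 1 `CSc1nc(NCCCc2ccccc2)c2ccccc2n1` carries a phenyl three bonds along the chain. In a functional assay on HT-29 cells (Homo sapiens) for cytotoxicity, read by MTT assay, with a stated time of 72 h (on this read-out lower numbers stand for stronger inhibition of growth and higher numbers for weaker inhibition of growth), compound 1 gives 89600 nM. Compound 2 `CSc1nc(NCCCCc2ccccc2)c2ccccc2n1` lengthens that chain. In this assay compound 2 reaches only the assay limit, > 100000 nM. The step of an at least 1.1-fold higher number from compound 1 to compound 2 (0.04 log units; that floor lies within the scatter) is therefore no more than a floor. Compound 3 `CSc1nc(NCc2ccccc2)c2ccccc2n1` carries the phenyl on the chain carbon bound to the ring nitrogen. In this assay compound 3 also returns a limit and not a number, > 100000 nM, so compound 3 stands at the weak end of what is shown, together with compound 2, because the limit of > 100000 nM in this assay, at which 2 of the 3 values shown sit, holds two of the three values.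

Compound 4 `CSc1nc(NCCCCCO)c2ccccc2n1` is defined by 4-hydroxybutyl in place of phenyl on a saturated chain carbon bound to a nitrogen on an aromatic ring. Going by the values given here, no measured step exchanges a phenyl for a hydroxyalkyl group; the only measured step, an at least 1.1-fold higher number from compound 1 to compound 2 (0.04 log units; that floor lies within the scatter), concerns chain length and lies within the scatter. With compound 3 at a limit, any change in this assay can only be expected as small or none beyond the scatter. Compound 4 is therefore estimated at 120000 nM, within 40000 nM to 400000 nM. The expected step that the limit leaves unreadable from compound 3 to compound 4 most likely stays at the assay limit.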

Compound 4, concentration for total growth inhibition: > 100000 nM
Compound 4: no number, only a limit; the forecaster's own chance of this, stated with the estimate: 70%; the middle value does not contradict the limit.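

In this assay compound 4 returns a limit and not a number, > 100000 nM. Going by these compounds alone, the steps from compound 2 and from compound 3 to compound 4 cannot be read, and the one readable step, an at least 1.1-fold higher number from compound 1 to compound 4 (0.04 log units; that floor lies within the scatter), is no more than a floor. The new point is that a chain with no ring, the 4-hydroxybutyl with its hydrogen-bond donor and acceptor, now stands at this position on a saturated chain carbon bound to a nitrogen on an aromatic ring and ends at the same limit as the phenyl-bearing chains of compound 2 and compound 3: the limit of > 100000 nM in this assay, at which 3 of the 4 values shown sit.

The compounds shown leave open whether an amine or a carboxylic acid in place of the hydroxyl of compound 4 would give a number in this assay and not a limit. They also leave open how phenyl and hydroxyl compare at the end of a chain on this core, as compound 1 alone gives a number.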